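A few compounds are considered here, and "the series" means these few. Any claim that something is new, unique, unknown or untested is made for them only; others in the source may bear on it.

Compound 3 `O=C1C(O)=C(C(c2ccc([N+](=O)[O-])cc2)c2c[nH]c3ccccc23)C(=O)c2ccccc21` gives the highest number of the three measured compounds in a functional assay on ECa-109 cells (Homo sapiens) for cytotoxicity, read by MTT assay, with a stated time of 48 h (on this read-out higher numbers stand for weaker inhibition and lower numbers for stronger inhibition), at 60900 nM. Compound 1 `COc1ccc(C(C2=C(O)C(=O)c3ccccc3C2=O)c2c[nH]c3ccccc23)cc1Br` gives 11800 nM in this assay, and compound 2 `Cc1[nH]c2ccccc2c1C(C1=C(O)C(=O)c2ccccc2C1=O)c1ccc(Cl)cc1` gives 14300 nM. Among the compounds with values here, the only single-point step among them, a 5.2-fold higher number from compound 1 to compound 3 (0.71 log units; beyond the scatter), concerns the group on the saturated chain carbon and not the change at hand. Compound 4 `Cc1[nH]c2ccccc2c1C(C1=C(O)C(=O)c2ccccc2C1=O)c1ccc([N+](=O)[O-])cc1` differs from compound 3 by methyl in place of hydrogen on an aromatic carbon. Within the data shown here, no measured step isolates this change; compounds 1 and 2 differ at this carbon but also elsewhere, and their two values lie within the scatter of each other. The estimate for compound 4 therefore expects no step beyond the scatter, a 1.2-fold lower number from compound 3 to compound 4 (0.09 log units; within the scatter). The expected value for compound 4 in this assay is 50000 nM, with a range from 20000 nM to 150000 nM.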

Compound 4, half-maximal inhibitory concentration: 6000 nM
Compound 4: the middle estimate sits 8.3-fold (0.92 log units) above what was measured; the measured number lies below the stated range.
By their numbers in this assay, from the lowest: compounds 4, 1 and 2 (each within the scatter of the next, the first and the last beyond it); then compound 3.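

In this assay, the methyl on the aromatic carbon next to the ring nitrogen gives a 10-fold lower number from compound 3 to compound 4 (1.01 log units; beyond the scatter) when measured alone, so this position strongly affects the read-out. With that methyl present, the nitro in place of chloro gives a 2.4-fold lower number from compound 2 to compound 4 (0.38 log units; beyond the scatter) on a second, separate change. Nothing available explains why the methyl has this effect.

On these data alone, whether the methyl gives a similar step alongside the 3-bromo-4-methoxyphenyl group of compound 1 remains open. So does what an ethyl group or an amine would do at the same carbon.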